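Oxetanyl-to-hydroxy swap on the amide nitrogen

A few compounds are considered here, and "the series" means these few. Any claim that something is new, unique, unknown or untested is made for them only; others in the source may bear on it.

Measured compounds:
compound 1 `CCN(Cc1ccsc1)C(=O)COc1ccc(C)cc1` — 88 nM
compound 2 `Cc1ccc(OCC(=O)N(Cc2cccs2)C2COC2)cc1` — 23000 nM
compound 3 `CCN(Cc1ccncc1)C(=O)COc1ccc(C)cc1` — "not active" (no number reported)

Three compounds share a phenoxyacetamide core and differ in the group on the amide nitrogen and in the ring of the methylene arm. In an assay on HEK293 cells for agonist activity at transient receptor potential cation channel subfamily M member 8 (Homo sapiens), read by fluorescence and calcium flux, with a stated time of 15 min (a higher number here means that more compound is needed for the effect, a lower number that less compound is needed), compound 1 gives 88 nM. Compound 2 gives 23000 nM, the highest of the two numbers available and well beyond the scatter from compound 1. Compound 3 is reported as "not active" (no number reported) without a number, and it also carries a different ring on the arm, so it does not speak to the nitrogen group alone.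

Compound 4 `Cc1ccc(OCC(=O)N(O)Cc2cccs2)cc1` is yet to be measured. Its change from compound 2: hydroxy in place of oxetan-3-yl on an amide-type nitrogen. Among the measured compounds shown here, no step between measured compounds isolates the nitrogen group. The number for compound 4 is expected to move below that of compound 2, in a step of a 4.6-fold lower number from compound 2 to compound 4 (0.66 log units; beyond the scatter), because compound 1 with its smaller nitrogen group gives 88 nM. Compound 4 is estimated at 5000 nM, within 800 nM to 40000 nM.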

Compound 4, half-maximal effective concentration: 8000 nM
Compound 4: the middle estimate sits 1.6-fold (0.20 log units) below what was measured, within the range that was stated.
By their numbers in this assay, from the lowest: compound 1; then compound 4; then compound 2.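

In this assay, among the compounds shown here, the swap of oxetan-3-yl for hydroxy on the amide-type nitrogen gives a 2.9-fold lower number from compound 2 to compound 4 (0.46 log units; beyond the scatter) and is the first step that changes this position alone. The number at this nitrogen therefore responds to the group placed there, even when a four-membered non-aromatic ring of 4 heavy atoms gives way to a hydroxy of 1 heavy atom that brings 1 hydrogen-bond donor. No measurement shown bears on why the number moves.

Open, going by these compounds, is whether a methoxy or a methyl group on this nitrogen, neither carrying a hydroxy hydrogen, would place the number nearer to that of compound 4 or of compound 2. Steps from compound 1 and compound 3 to the other compounds cannot be read, as each differs from them in more than one place.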